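This account rests on a few compounds, and the source may have more. Where it says the series, first, only, none or still open, it means among the compounds named here.

Working notes on the series.

Compound 1 `CC1=CC[C@@H]2[C@@H](O[C@H](c3ccc(Cl)cc3)OC2(C)C)[C@@H]1O` is the reference point. Among the compounds with values here, in a functional assay on the whole organism (Abdomen, strain albino) for inhibition, with Mus musculus as the target, in the writhing test, with stated times of 1 h and 8 min, at a dose of 10 mg/kg by the oral route (on this read-out higher numbers stand for more inhibition at the one dose given (going by the name of the read-out) and lower numbers for less inhibition), compound 1 gives 88% and stands highest of the two numbers measured so far; its nearest neighbour is compound 2 `CC1=CC[C@@H]2[C@@H](O[C@H](c3cccc(Cl)c3)OC2(C)C)[C@@H]1O`, which gives 27% in this assay. Within the data shown here, the one step measured between them, a number 61 percentage points lower from compound 1 to compound 2 (beyond the scatter), is large and beyond the scatter, but it moves a substituent around the ring rather than exchanging it.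

Compound 3 `CC1=CC[C@@H]2[C@@H](O[C@H](c3ccc(C(F)(F)F)cc3)OC2(C)C)[C@@H]1O` differs from compound 1 by trifluoromethyl in place of chloro on an aromatic carbon. Among the measured compounds shown here, no measured step swaps one group for another on that ring, so the step from compound 1 to compound 2 does not bear directly on it; the only guidance is that compound 1 itself sits high in this assay. The expectation is therefore a modest fall, a number 18 percentage points lower from compound 1 to compound 3 (beyond the scatter), with wide uncertainty. Compound 3 is estimated at 70%, within a range of 35% to 95%.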

Compound 3, a percentage reported as inhibition, in the whole organism at one dose (the size of the read-out at that dose, not a potency): 52%
Beside the measured number, compound 3's estimate is 18 percentage points above it; low and high end bracket the measured number.
By their numbers in this assay, from the lowest: compound 2; then compound 3; then compound 1.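

In this assay the group changes while its place stays the same, on an aromatic carbon para to a large group, and the result is a number 36 percentage points lower from compound 1 to compound 3 (beyond the scatter), so the read-out depends on which group sits there as well as on where it stands. The exchange raises the heavy atoms of the group from 1 to 4 and leaves its hydrogen-bond donors and acceptors at 0, but a single exchange cannot tie the fall to any one of these counts. No measurement on hand accounts for the fall.

The compounds shown leave open whether another group at this place, such as methoxy, an amine or a carboxylic acid, would match compound 1 or fall further. On these data alone, whether trifluoromethyl responds to a move around the ring as chloro does also remains open.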